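This account rests on a few compounds, and the source may have more. Where it says the series, first, only, none or still open, it means among the compounds named here.

For the measured compounds named here, compound 2, `CC(C)Oc1ccccc1OC(C)C1=NCCN1`, gives the lowest of the two numbers measured so far: in an assay on CHO cells for displacement of a labelled ligand from Alpha-2C adrenergic receptor (Homo sapiens) (a higher number here means a weaker inhibitor, a lower number a stronger inhibitor), compound 2 gives 398 nM. Going by the values given here, its only neighbour is compound 1, `CCOc1ccccc1OC(C)C1=NCCN1`, which in this assay gives 759 nM; the step of a 1.9-fold lower number from compound 1 to compound 2 (0.28 log units; within the scatter) lies within the scatter. Compound 3, `CC(Oc1ccccc1C=O)C1=NCCN1`, differs from compound 2 by formyl in place of isopropoxy on an aromatic carbon. Among the compounds with values here, the one measured step concerns only the size of the alkyl group on the aromatic ether oxygen, whereas here the isopropoxy group itself is exchanged for formyl, so that step bears on the new change only loosely and gives no direction. Within the data shown here, with no closer precedent, compound 3 is expected to give a number not far from that of compound 2, a step of a 1.5-fold higher number from compound 2 to compound 3 (0.18 log units; within the scatter) within the scatter, though the range is wide. Compound 3 is estimated at 600 nM, between 150 nM and 2500 nM.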

Compound 3, inhibition constant: 8710 nM
For compound 3 the middle estimate is 15-fold (1.16 log units) below the measured one; measured number above the stated range.
By their numbers in this assay, from the lowest: compounds 2 and 1 (each within the scatter of the next); then compound 3.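

The aromatic carbon that carries the ether group proved sensitive to what stands on it. In this assay, formyl in place of isopropoxy gives a large change (a 22-fold higher number from compound 2 to compound 3 (1.34 log units; beyond the scatter)), and formyl in place of ethoxy gives another (an 11-fold higher number from compound 1 to compound 3 (1.06 log units; beyond the scatter)), whereas the earlier change within the ether chain stayed within the scatter. No measurement at hand explains these steps.

The compounds shown leave open whether the higher number goes with the loss of the ether oxygen on the aromatic carbon, with the carbonyl of the formyl group, or with the smaller count of heavy atoms. A methoxy group, a hydroxyl group, an acetyl group or a plain ethyl chain on this carbon would help to tell these readings apart.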